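This account rests on a few compounds, and the source may have more. Where it says the series, first, only, none or still open, it means among the compounds named here.

Measured so far:
Compound 1 `O=C(CCc1ccccc1)Nc1nnc(-c2ccc3c(c2)OCCO3)s1` gives 32.5 ug/mL in a functional assay on HeLa cells (Homo sapiens) for antiproliferative activity, read by MTT assay, with a stated time of 48 h; on this read-out higher numbers stand for an effect only at larger amounts of compound and lower numbers for an effect already at smaller amounts.
Compound 2 `O=C(/C=C/c1ccccc1)Nc1nnc(-c2ccc3c(c2)OCCO3)s1` gives only a limit, > 100 ug/mL, in this assay.

In this assay compound 2 stands at the limit of the measurement rather than at a number; of the two values, it is the one sitting at the limit of > 100 ug/mL in this assay, at which 1 of the 2 values shown sits. For the measured compounds named here, the only measured step, an at least 3.0-fold higher number from compound 1 to compound 2 (0.48 log units; beyond the scatter), carried the number up to that limit. Compound 3 `O=C(Nc1nnc(-c2ccc3c(c2)OCCO3)s1)c1ccccn1` differs from compound 2 by pyridin-2-yl in place of 2-phenylethenyl on a carbonyl carbon. Going by the values given here, no measured step contains this exact change; the one measured step swaps groups at the same carbonyl carbon and is the only guide. Since compound 2 offers no number, the size of the coming step is open. Compound 3 is expected to come back toward the number shown by compound 1, though it may well remain at the limit. That amounts to an expected at least 2.2-fold lower number from compound 2 to compound 3 (0.34 log units; beyond the scatter) in this assay. The estimate for compound 3 is 45 ug/mL, from 15 ug/mL to 120 ug/mL.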

Compound 3, half-maximal effective concentration: > 100 ug/mL
Compound 3: a limit, no number; the forecaster's own chance of this, stated with the estimate: 40%; middle value at least 2.2-fold (0.34 log units) from the limit.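

In this assay compound 3 gives > 100 ug/mL, which is a limit of the assay and not a number. For the compounds shown here, putting pyridin-2-yl in place of phenethyl on the carbonyl carbon gives an at least 3.0-fold higher number from compound 1 to compound 3 (0.48 log units; beyond the scatter), so 2-phenylethenyl is no longer the only group at this position that leaves the number of compound 1 behind. The step between compound 2 and compound 3 cannot be read, since neither compound has a number to compare: the limit of > 100 ug/mL in this assay, at which 2 of the 3 values shown sit.

Going by these compounds alone, compound 1, at 32.5 ug/mL, remains the only compound here with an actual number, so phenethyl is the only group at this position with a measured effect. Going by these compounds, whether a longer chain such as 3-phenylpropyl, or a phenethyl group carrying an amine on its ring, would give a lower number than compound 1 remains open.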